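Halogen to Methoxy on a Weakly Active Pair

The compounds below may be only part of what the source reports. "The series", "measured", "known", "first", "only" and "open" are said of these compounds alone.

Measured compounds:
Compound 1, `CC(C)(C)NCc1c(C(=O)O)nn(-c2ccc(Cl)cc2)c1-c1ccc(Cl)cc1`, gives 518000 nM.
Compound 2, `CC(C)(C)NCc1c(C(=O)O)nn(-c2ccc(Cl)cc2)c1-c1ccc(Br)cc1`, gives > 542000 nM.

Both were tested in a functional assay on U-251 cells (Homo sapiens) for inhibition, read by sulforhodamine B assay, with a stated time of 48 h; on this read-out lower numbers stand for stronger inhibition of growth and higher numbers for weaker inhibition of growth. Compound 1 reaches only a very high concentration, 518000 nM, so its effect on cell growth is weak. For compound 2 the assay reports a limit rather than a number, > 542000 nM. Compound 2 thus stands at the upper edge of what was measured, as shown by the limit of > 542000 nM in this assay, at which 1 of the 2 values shown sits.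

Compound 3, `COc1ccc(-c2c(CNC(C)(C)C)c(C(=O)O)nn2-c2ccc(Cl)cc2)cc1`, is the unmeasured partner. It differs from compound 2 by methoxy in place of bromo on an aromatic carbon. Within the data shown here, only one measured step exists, an at least 1.0-fold higher number from compound 1 to compound 2 (0.01 log units; that floor lies within the scatter), and it concerns a swap of one halogen for another, not the entry of methoxy, so it bears on the present step only loosely; it shows that altering this position left both compounds within the scatter of each other. No large shift is expected in this assay. The step of an at least 1.0-fold lower number from compound 2 to compound 3 (0.03 log units; that floor lies within the scatter) is the expected outcome. Compound 3 is therefore estimated at 500000 nM, with a range from 200000 nM to 1200000 nM, and a fair chance that the assay again reports only a limit.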

Compound 3, concentration for 50% growth inhibition: 498000 nM
The estimate for compound 3 lay 1.0-fold (0.00 log units) above the measured number, and the stated range covers the measured number.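

Compound 3 puts a group other than a halogen on this aromatic carbon, and in this assay it returns a real number that can be set against compound 1 (a 1.0-fold lower number from compound 1 to compound 3 (0.02 log units; within the scatter)). So on this shared core, replacing chloro with methoxy, a group with one more heavy atom and a hydrogen-bond acceptor, brings no change that stands out from the usual variation between repeat measurements, and growth inhibition remains weak. The comparison with the bromo compound points the same way but is less firm, since it gives only a minimum size for the step (an at least 1.0-fold lower number from compound 2 to compound 3 (0.03 log units; that floor lies within the scatter)), and compound 2 has a limit rather than a number: the limit of > 542000 nM in this assay, at which 1 of the 3 values shown sits.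

Whether an amine or a longer chain such as butoxy at this same place would move the number beyond the scatter stays open, since the three groups shown here all leave it in the same high range. Going by these compounds, it is also open whether an amide in place of the carboxylic acid, elsewhere on the shared core, would give stronger inhibition of growth.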